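This account rests on a few compounds, and the source may have more. Where it says the series, first, only, none or still open, it means among the compounds named here.

Compounds measured so far in an assay for inhibition of Indoleamine 2,3-dioxygenase 1 (Homo sapiens), read by fluorescence, with a stated time of 1 h; a higher number here means a weaker inhibitor, a lower number a stronger inhibitor:
compound 1 `NS(=O)(=O)CC(=O)NCCSc1nonc1/C(=N/O)Nc1cccc(Cl)c1` gives 21 nM
compound 2 `NS(=O)(=O)CC(=O)NCCSc1nonc1/C(=N/O)Nc1ccc(F)c(C(F)F)c1` gives 73 nM
compound 3 `NS(=O)(=O)CC(=O)NCCSc1nonc1/C(=N/O)Nc1ccc(F)c(Br)c1` gives 71 nM

Compound 3 stands second highest of the three numbers in this assay. Its nearest neighbour is compound 2, whose number is within the scatter of that of compound 3, so no order can be read between them. Compound 1 is the furthest away, with a 3.4-fold higher number from compound 1 to compound 3 (0.53 log units; beyond the scatter) separating the two.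

Compound 4 `N#Cc1cccc(N/C(=N\O)c2nonc2SCCNC(=O)CS(N)(=O)=O)c1` has not yet been measured in this assay. It differs from compound 3 in one place: 3-cyanophenyl in place of 3-bromo-4-fluorophenyl on an amine nitrogen. Going by the values given here, two measured steps bear on this change. The step of a 1.0-fold lower number from compound 2 to compound 3 (0.01 log units; within the scatter) shows that exchanging one group on the aromatic carbon made no difference beyond the scatter. The step of a 3.4-fold higher number from compound 1 to compound 3 (0.53 log units; beyond the scatter) shows that moving from a phenyl ring bearing one group to one bearing two raised the number modestly. Compound 4 again carries a single group on its phenyl ring, as compound 1 does, but a nitrile has not been tried here, so the evidence is indirect. A modest lowering is therefore expected from compound 3 to compound 4, estimated as a 1.8-fold lower number from compound 3 to compound 4 (0.25 log units; within the scatter), though it may well fall within the scatter. Compound 4 is expected to give about 40 nM in this assay, with a range from 12 nM to 130 nM.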

Compound 4, half-maximal inhibitory concentration: 240 nM
Compound 4: middle estimate off by 6.0-fold (0.78 log units), on the low side; measured number outside the range, above it.
By their numbers in this assay, from the lowest: compound 1; then compounds 3 and 2 (each within the scatter of the next); then compound 4.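

With the group count held at one, the exchange on the aromatic carbon in this assay gives an 11-fold higher number from compound 1 to compound 4 (1.06 log units; beyond the scatter) and is the largest step in this set, so this position responds strongly to which single group it carries. The earlier comparison of one-group and two-group rings had not shown this: compound 1 and compound 4 each bear one group on the ring yet stand at opposite ends of the series, so a single group does not by itself give the lower number. The 3-cyanophenyl ring also compares unfavourably with both two-group rings, with a 3.4-fold higher number from compound 3 to compound 4 (0.53 log units; beyond the scatter) and a 3.3-fold higher number from compound 2 to compound 4 (0.52 log units; beyond the scatter) both beyond the scatter, and nothing in the information available explains these differences.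

From the compounds shown here alone, whether a methyl or methoxy group in place of the chloro would stay near compound 1 or fall towards compound 4 remains open. The compounds shown also leave the contribution of the fluoro group in compound 2 and compound 3 unseparated from that of the group accompanying it, and they leave open whether adding fluoro to the 3-cyanophenyl ring would change the number.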